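Ortho substituent series on the shared imidazoline ether core

The source may hold more compounds than are shown below. What is called first, only, known or untested is meant among the compounds shown, and "the series" means these compounds.

Among the compounds with values here, compound 3 `CC(Oc1ccccc1OC1CC1)C1=NCCN1` gives the highest number of the three measured so far: in a functional assay on CHO cells for agonist activity at Alpha-2B adrenergic receptor (Homo sapiens) (on this read-out higher numbers stand for an effect only at larger amounts of compound and lower numbers for an effect already at smaller amounts), compound 3 gives 12900 nM, whereas compound 1 `CC(Oc1ccccc1Br)C1=NCCN1` gives 316 nM and compound 2 `CC(C)Oc1ccccc1OC(C)C1=NCCN1` gives 1740 nM. Compound 4 `CC(Oc1ccccc1S(C)(=O)=O)C1=NCCN1` differs from compound 3 by methylsulfonyl in place of cyclopropyloxy on an aromatic carbon. Within the data shown here, no measured step introduces methylsulfonyl; the steps that touch the same aromatic carbon are a 41-fold higher number from compound 1 to compound 3 (1.61 log units; beyond the scatter), a 5.5-fold higher number from compound 1 to compound 2 (0.74 log units; beyond the scatter) and a 7.4-fold higher number from compound 2 to compound 3 (0.87 log units; beyond the scatter), all raising the number. Since compound 3 already sits at the top, a moderate drop is expected for compound 4 in this assay, as a 5.2-fold lower number from compound 3 to compound 4 (0.71 log units; beyond the scatter). Compound 4 is estimated at 2500 nM, within 500 nM to 12000 nM.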

Compound 4, half-maximal effective concentration: 10000 nM
Compound 4: the middle estimate sits 4.0-fold (0.60 log units) below what was measured; the measured number falls inside the stated range.
By their numbers in this assay, from the lowest: compound 1; then compound 2; then compounds 4 and 3 (each within the scatter of the next).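

In this assay the change shows a 1.3-fold lower number from compound 3 to compound 4 (0.11 log units; within the scatter), so methylsulfonyl, with no ring and two double bonds outside aromatic rings, stands level with cyclopropyloxy on this aromatic carbon. Bromo stays apart from both, with a 32-fold higher number from compound 1 to compound 4 (1.50 log units; beyond the scatter) on going to methylsulfonyl, and isopropoxy also differs from methylsulfonyl, with a 5.7-fold higher number from compound 2 to compound 4 (0.76 log units; beyond the scatter) on the same carbon. Nothing available bears on the reason for these steps.

As far as these compounds go, what an amine or a carboxylic acid on this aromatic carbon would give stays open. So does whether any group here reaches a lower number than bromo.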